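The compounds below may be only part of what the source reports. "The series", "measured", "known", "first", "only" and "open" are said of these compounds alone.

Working notes on the series, measured in an assay on HEK293 cells for inhibition of Steryl-sulfatase (Homo sapiens), tested at 0.1 uM; on this read-out lower numbers stand for a weaker effect and higher numbers for a stronger effect at the one concentration tested. Compound 1 `NS(=O)(=O)Oc1ccc2c(c1)CN(C(=O)c1cccc(N3CCC(Cc4ccccc4)CC3)c1)CC2` gives 1.4%, compound 2 `CCN(Cc1ccccn1)c1cccc(C(=O)N2CCc3ccc(OS(N)(=O)=O)cc3C2)c1` gives 6.5%, and compound 3 `CN(C)CCCN(Cc1ccccc1)c1ccc(C(=O)N2CCc3ccc(OS(N)(=O)=O)cc3C2)cc1` gives 16.2%. Compound 3 holds the highest of the three numbers; its gap to compound 2 lies within the usual scatter, while its gap to compound 1 lies beyond it. Compound 4 `NS(=O)(=O)Oc1ccc2c(c1)CN(C(=O)c1ccc(N(Cc3ccccc3)Cc3ccco3)cc1)CC2` has not been measured. It differs from compound 3 in one place: furan-2-yl in place of 2-(dimethylamino)ethyl on a saturated chain carbon bound to a nitrogen on an aromatic ring. Within the data shown here, no step between measured compounds isolates this kind of change, and all three measured numbers sit low. The step is expected to be small and downward, a number 8.2 percentage points lower from compound 3 to compound 4 (within the scatter), and not beyond the scatter. For compound 4 the expected value is 8%, with a range from -5% to 25%.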

Compound 4, a percentage reported as inhibition, at one concentration (the size of the read-out at that concentration, not a potency): 90.8%
The estimate for compound 4 lay 82.8 percentage points below the measured number; the whole stated range lies below it.
By their numbers in this assay, from the lowest: compounds 1, 2 and 3 (each within the scatter of the next, the first and the last beyond it); then compound 4.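

On a saturated chain carbon bound to a nitrogen on an aromatic ring, furan-2-yl in place of 2-(dimethylamino)ethyl gives a number 74.6 percentage points higher from compound 3 to compound 4 (beyond the scatter) and so shows this place to be highly sensitive to the group it carries. The two groups match in heavy atoms and hydrogen-bond acceptors and carry no net charge, so these counts do not separate them, while the ring, the oxygen and the loss of the amine all change together. Nothing available explains the size of this step. Among these compounds, with only this one pair, it remains open whether the gain follows the furan ring or the absence of the amine. Thiophen-2-yl, phenyl or a plain propyl chain at this place would separate the two.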